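The source may hold more compounds than are shown below. What is called first, only, known or untested is meant among the compounds shown, and "the series" means these compounds.

- compound 1 `Cc1cc(C(=O)Nc2cc(Oc3ccc4nc(NC(=O)C5CC5)nn4c3)ccc2C)n(C)n1`: 1.3 nM
- compound 2 `Cc1cc(NC(=O)c2cc(C)nn2C)cc(Oc2ccc3nc(NC(=O)C4CC4)nn3c2)c1`: 47 nM
- compound 3 `Cc1cc(C(=O)Nc2cccc(Oc3ccc4nc(NC(=O)C5CC5)cn4c3)c2)n(C)n1`: 1.1 nM

In a functional assay on HUVEC cells (Homo sapiens) for antiproliferative activity, read by WST assay, with a stated time of 5 days (a higher number here means a weaker inhibitor, a lower number a stronger inhibitor), compound 1 gives 1.3 nM. This is within the usual scatter of compound 3 at 1.1 nM, while compound 2 shows a far higher number at 47 nM.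

Compound 4 `Cc1ccc(Oc2ccc3nc(NC(=O)C4CC4)nn3c2)cc1NC(=O)c1ccnn1C` differs from compound 1 in one place: hydrogen in place of methyl on an aromatic carbon. Hydrogen stands in place of methyl on an aromatic carbon, turning 1,3-dimethyl-1H-pyrazol-5-yl into 1-methyl-1H-pyrazol-5-yl. Within the data shown here, no measured pair shows this change, so the guidance is indirect. In this assay, a slightly higher number is expected, but no step beyond the scatter. The estimate is a 1.9-fold higher number from compound 1 to compound 4 (0.28 log units; within the scatter). Compound 4 is expected at 2.5 nM, within an estimated range of 0.8 nM to 10 nM.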

Compound 4, half-maximal inhibitory concentration in the HUVEC assay: 9.9 nM
The estimate for compound 4 lay 4.0-fold (0.60 log units) below the measured number, within the range that was stated.
By their numbers in the HUVEC assay, from the lowest: compounds 3 and 1 (each within the scatter of the next); then compound 4; then compound 2.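

Among these compounds, in the HUVEC assay, hydrogen in place of methyl on this aromatic carbon of the pyrazole gives a 7.6-fold higher number from compound 1 to compound 4 (0.88 log units; beyond the scatter), the first view of this single position, since the earlier compounds offered no pair differing in one place. In a physicochemical assay for solubility, measured as kinetic solubility, at pH 6.8 (on this read-out higher numbers stand for higher solubility and lower numbers for lower solubility), compound 1 gives 53 ug/mL. In the same assay, compound 4 gives > 80 ug/mL, which is a limit of the assay: the limit of > 80 ug/mL in the physicochemical assay, at which 1 of the 2 values shown sits. Going by these compounds, what an ethyl or a methoxy group on this carbon would do in the HUVEC assay remains open, and so does its effect in the physicochemical assay.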